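This account rests on a few compounds, and the source may have more. Where it says the series, first, only, none or still open, it means among the compounds named here.

In a toxicity assay on MRC5 cells (Homo sapiens) for inhibition, read by MTT assay, with a stated time of 72 h (a lower number here means a stronger inhibitor, a higher number a weaker inhibitor), compound 1 `O=C(Nc1cccc(OCc2cn(-c3cccc(Br)c3)nn2)c1)Nc1ccc(Cl)c(C(F)(F)F)c1` gives 11900 nM. Compound 2 `O=C(Nc1cccc(OCc2cn(-c3ccccc3I)nn2)c1)Nc1ccc(Cl)c(C(F)(F)F)c1` gives 21900 nM, and the step of a 1.8-fold higher number from compound 1 to compound 2 (0.26 log units; within the scatter) stays within the scatter, so compound 2 stands within the scatter of compound 1 on the numbers shown. Compound 3 `O=C(Nc1cccc(OCc2cn(-c3ccccc3C(F)(F)F)nn2)c1)Nc1ccc(Cl)c(C(F)(F)F)c1` carries trifluoromethyl in place of iodo on an aromatic carbon. Among the measured compounds shown here, the one measured step also exchanged the group on that ring and moved nothing beyond the scatter, so nothing here points to a larger shift. Compound 3 is therefore expected to give 20000 nM, between 8000 nM and 50000 nM, an estimated step of a 1.1-fold lower number from compound 2 to compound 3 (0.04 log units; within the scatter) that would remain within the scatter.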

Compound 3, half-maximal inhibitory concentration: 8230 nM
The estimate for compound 3 lay 2.4-fold (0.39 log units) above the measured number; low and high end bracket the measured number.
By their numbers in this assay, from the lowest: compounds 3, 1 and 2 (each within the scatter of the next, the first and the last beyond it).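

In this assay, among the compounds shown here, trifluoromethyl in place of iodo on this aromatic carbon gives a 2.7-fold lower number from compound 2 to compound 3 (0.43 log units; beyond the scatter), the first step to pass beyond the scatter, though only modestly. By contrast, a 1.4-fold lower number from compound 1 to compound 3 (0.16 log units; within the scatter), so this exchange separates compound 3 from compound 2 but not from compound 1. No measurement shown accounts for the step. From the compounds shown here alone, whether an amine, a carboxylic acid or a methoxy group at this place would move the number further remains open. So does whether the same exchange elsewhere on the ring would give a similar step.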